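Swapping the ring on the carbonyl carbon of compound 3

The source may hold more compounds than are shown below. What is called first, only, known or untested is meant among the compounds shown, and "the series" means these compounds.

In a functional assay on A549 cells (Homo sapiens) for cytotoxicity, read by LDH release, with a stated time of 48 h (a higher number here means a weaker inhibitor, a lower number a stronger inhibitor), three compounds have been measured. Compound 1 (`O=C(COc1c(F)cc(C(=O)c2ccc(F)cc2)cc1Cl)NNC(=O)c1ccc(=O)oc1`) gives 60200 nM, and compound 2 (`Cc1ccc(C(=O)c2cc(F)c(OCC(=O)NNC(=O)c3ccc(=O)oc3)c(Cl)c2)cc1`) gives 21400 nM. Compound 3 (`Cn1cnc(C(=O)NNC(=O)COc2c(F)cc(C(=O)c3ccc(Cl)cc3)cc2Cl)c1`) gives 45800 nM, within the scatter of compound 1 and higher than compound 2 by more than the scatter.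

Compound 4 (`O=C(COc1c(F)cc(C(=O)c2ccc(Cl)cc2)cc1Cl)NNC(=O)c1ccc(=O)oc1`) departs from compound 3 in one place: a group of 7 heavy atoms (5 carbon, 2 oxygen; one six-membered aromatic ring with 1 hetero atom) in place of a group of 6 heavy atoms (4 carbon, 2 nitrogen; one five-membered aromatic ring with 2 hetero atoms), on a carbonyl carbon. Among the measured compounds shown here, the 1-methyl-1H-imidazol-4-yl group leaves the carbonyl carbon, and the group that enters is the one already carried by compound 1 and compound 2. For the measured compounds named here, no measured pair isolates this exchange. Going by the values given here, the only measured step, with methyl in place of fluoro on an aromatic carbon, is a 2.8-fold lower number from compound 1 to compound 2 (0.45 log units; beyond the scatter). It is modest and lies elsewhere in the molecule, so it bears on the change only indirectly, by showing how far values move among compounds carrying the entering group. Compound 4 keeps the aromatic substituent of compound 3, which matches neither compound 1 nor compound 2, so a value near those two is a reasonable expectation.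

The expected change is a 1.4-fold lower number from compound 3 to compound 4 (0.14 log units; within the scatter), a small step in the direction of a lower number. For compound 4 the estimated value is 33000 nM, with an expected range from 15000 nM to 70000 nM.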

Compound 4, half-maximal inhibitory concentration: 84900 nM
Compound 4: the middle estimate sits 2.6-fold (0.41 log units) below what was measured, outside the stated range (above it).
By their numbers in this assay, from the lowest: compound 2; then compounds 3, 1 and 4 (each within the scatter of the next).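

In this assay, among the compounds shown here, the exchange on the carbonyl carbon, measured here for the first time, gives a 1.9-fold higher number from compound 3 to compound 4 (0.27 log units; within the scatter) and so does not separate the entering group from the 1-methyl-1H-imidazol-4-yl group. The new compound also shows that the substituent on the aromatic carbon matters unevenly among compounds carrying the entering group: chloro in place of fluoro gives a 1.4-fold higher number from compound 1 to compound 4 (0.15 log units; within the scatter) and stays unresolved, whereas chloro in place of methyl gives a 4.0-fold higher number from compound 2 to compound 4 (0.60 log units; beyond the scatter) and is a modest step beyond the scatter, so that among these three compounds only the methyl compound stands apart. No measurement shown here accounts for either of these steps.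

Whether the 1-methyl-1H-imidazol-4-yl group would also sit level with the entering group when methyl rather than chloro is on the aromatic carbon remains open, since the one exchange shown carries chloro. The compounds also leave open how a phenyl ring or a simple amine on the carbonyl carbon, or a methoxy or ethyl group on the aromatic carbon, would read in this assay.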